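The source may hold more compounds than are shown below. What is called first, only, known or untested is meant among the compounds shown, and "the series" means these compounds.

In an ADME assay on Vero cells (Chlorocebus sabaeus) for cytotoxicity, read by crystal violet staining (a higher number here means that more compound is tolerated, a lower number that less compound is tolerated), compound 1 `CN(C)CCCN(/N=N/c1ccc([N+](=O)[O-])cc1)c1ccccc1` gives 40000 nM and compound 2 `CN(C)CCCN(/N=N/c1cccc([N+](=O)[O-])c1)c1ccccc1` gives 40000 nM, so the two stand level and compound 2 sits at the low end of the numbers in hand. Compound 3 `CN(/N=N/c1cccc([N+](=O)[O-])c1)c1ccccc1` reads > 100000 nM, and this is a limit of the assay, not a number (the limit of > 100000 nM in this assay, at which 1 of the 3 values shown sits). For the measured compounds named here, the one measured step, with hydrogen in place of 2-(dimethylamino)ethyl on a saturated chain carbon bound to a nitrogen on an aromatic ring, is an at least 2.5-fold higher number from compound 2 to compound 3 (0.39 log units; beyond the scatter), and it leaves the nitro group untouched. Compound 4 `CN(C)CCCN(/N=N/c1ccccc1)c1ccccc1` now brings a different change to compound 2, with hydrogen in place of nitro on an aromatic carbon. Going by the values given here, no measured step removes a nitro group, so that step gives only weak guidance on size and none on direction. Little movement is therefore expected in this assay, and the estimated change is a 1.1-fold higher number from compound 2 to compound 4 (0.05 log units; within the scatter). For compound 4 the expected value is 45000 nM, with an estimated range from 18000 nM to 100000 nM.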

Compound 4, half-maximal cytotoxic concentration: 35000 nM
For compound 4 the middle estimate is 1.3-fold (0.11 log units) above the measured one; low and high end bracket the measured number.
By their numbers in this assay, from the lowest: compounds 4, 1 and 2 (each within the scatter of the next). At a limit, above all of these: compound 3.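

In this assay, for the compounds shown here, the nitro group on this aromatic carbon, meta to a large group, is the first to be exchanged, and hydrogen in its place gives a 1.1-fold lower number from compound 2 to compound 4 (0.06 log units; within the scatter). The same exchange from the other nitro compound gives a 1.1-fold lower number from compound 1 to compound 4 (0.06 log units; within the scatter) and so, in this small set carrying the longer nitrogen substituent, the presence of a nitro group at either of these two places makes no difference beyond the scatter. The data shown offer no cause for this lack of movement.

From the compounds shown here alone, it remains open whether an amine or a carboxylic acid on this aromatic carbon would leave the number just as level as hydrogen does. Going by these compounds, it is also open how a longer chain on the nitrogen would read against compound 4.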